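Compound 3: moving the pyridine attachment

The compounds below may be only part of what the source reports. "The series", "measured", "known", "first", "only" and "open" are said of these compounds alone.

Compound 1 `CN(C)Cc1csc(NC(=O)c2cc(C(C)(C)C)nn2Cc2ccccc2)n1` gives 25 ug/mL
Compound 2 `CC(C)(C)c1cc(C(=O)Nc2ccccn2)n(Cc2ccccc2)n1` gives 6.3 ug/mL

In a physicochemical assay for solubility, read by nephelometry, measured as kinetic solubility, at pH 6.5 (on this read-out higher numbers stand for higher solubility and lower numbers for lower solubility), compound 2 holds the lower of the two numbers, at 6.3 ug/mL against the higher number of compound 1. Compound 3 `CC(C)(C)c1cc(C(=O)Nc2ccncc2)n(Cc2ccccc2)n1` has not yet been measured. It carries pyridin-4-yl in place of pyridin-2-yl on an amide-type nitrogen.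

Among the measured compounds shown here, only one measured step bears on this change, since it falls at the same place: a 4.0-fold lower number from compound 1 to compound 2 (0.60 log units; beyond the scatter), with pyridin-2-yl in place of 4-((dimethylamino)methyl)-1,3-thiazol-2-yl. That modest step shows that the number can move with the group on this nitrogen. It says nothing about moving between two pyridinyl groups, so the direction rests on judgement alone. Compound 2 and compound 3 have the same atoms, so a smaller shift than that step is expected, leaning slightly upward and probably not beyond the scatter. The expected change is a 1.7-fold higher number from compound 2 to compound 3 (0.24 log units; within the scatter) in this assay on this estimate. Compound 3 is estimated at 11 ug/mL, with an expected range from 4 ug/mL to 30 ug/mL in this read-out.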

Compound 3, solubility: 6.3 ug/mL
For compound 3 the middle estimate is 1.7-fold (0.24 log units) above the measured one; the range from low to high includes it.
By their numbers in this assay, from the lowest: compounds 2 and 3 (each within the scatter of the next); then compound 1.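

In this assay, among the compounds shown here, moving the pyridine attachment gave no change at the digits printed from compound 2 to compound 3 (within the scatter) and so pyridin-2-yl and pyridin-4-yl on this amide-type nitrogen cannot be told apart on this read-out, which the earlier pair could not show with only one pyridinyl group among them. The step away from 4-((dimethylamino)methyl)-1,3-thiazol-2-yl also now stands with a second pyridinyl group, as a 4.0-fold lower number from compound 1 to compound 3 (0.60 log units; beyond the scatter) matches the earlier step, so at this level the difference from compound 1 does not depend on which of these two pyridinyl groups is present. Nothing measured here accounts for either the flat result or the difference from compound 1.

The compounds shown leave open whether pyridin-3-yl on the same nitrogen would fall with compound 2 and compound 3, and whether a pyridinyl group carrying a dimethylaminomethyl chain would come closer to compound 1. They also do not separate the share of the thiazolyl ring from that of its dimethylaminomethyl chain in the higher number of compound 1.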